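From isopropylamino to ethylsulfanyl on the carbonyl carbon

The source may report more compounds than this note shows. Statements on the series, on what has been measured and on what is new or still open speak of the compounds shown alone.

Measured compounds in an assay on membranes from CHO cells for displacement of a labelled ligand from adenosine receptor A1 (Homo sapiens), read by scintillation counting, with a stated time of 60 min, tested at 1 uM; on this read-out higher numbers stand for more inhibition at the one concentration tested (going by the name of the read-out) and lower numbers for less inhibition:
compound 1 `CC1=C(C(=O)C2CC2)C(c2ccco2)NC(=O)N1`: 2%
compound 2 `CCCC(=O)C1=C(C)NC(=O)NC1c1ccco1`: 1%
compound 3 `CC1=C(C(=O)NC(C)C)C(c2ccco2)NC(=O)N1`: 3%

Compound 3 has the highest of the three numbers, yet its steps to compound 1 and compound 2, a number 1 percentage points higher from compound 1 to compound 3 (within the scatter) and a number 2 percentage points higher from compound 2 to compound 3 (within the scatter), both lie within the scatter, so the three are indistinguishable. Compound 4 `CCSC(=O)C1=C(C)NC(=O)NC1c1ccco1` differs from compound 3 by ethylsulfanyl in place of isopropylamino on a carbonyl carbon. Among the measured compounds shown here, the steps that bear on this are the earlier exchanges on the same carbonyl carbon, a number 1 percentage points lower from compound 1 to compound 2 (within the scatter), a number 1 percentage points higher from compound 1 to compound 3 (within the scatter) and a number 2 percentage points higher from compound 2 to compound 3 (within the scatter), none of them beyond the scatter. Compound 4 is therefore expected to show no step beyond the scatter, no change at the digits printed from compound 3 to compound 4 (within the scatter). Compound 4 is estimated at 3%, between -5% and 12%.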

Compound 4, a percentage reported as inhibition, at one concentration (the size of the read-out at that concentration, not a potency): 6%
The estimate for compound 4 lay 3 percentage points below the measured number; the measured number falls inside the stated range.
By their numbers in this assay, from the lowest: compounds 2, 1, 3 and 4 (each within the scatter of the next).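

Ethylsulfanyl brings a sulfur-linked group to the carbonyl carbon, and in this assay the steps read a number 3 percentage points higher from compound 3 to compound 4 (within the scatter) and a number 5 percentage points higher from compound 2 to compound 4 (within the scatter) and a number 4 percentage points higher from compound 1 to compound 4 (within the scatter) with none beyond the scatter. Replacing isopropylamino, propyl or cyclopropyl with ethylsulfanyl therefore does not set compound 4 apart, and all four compounds remain indistinguishable. Nothing available bears on why this exchange leaves the read-out within the scatter.

From the compounds shown here alone, whether a carboxylic acid, a primary amine or a longer chain on this carbonyl carbon would give a step beyond the scatter remains open. So does whether any change elsewhere on the shared core would do so.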